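Chlorine Position Shift in a Pyridine Series: Cytotoxicity Outlook

This account rests on a few compounds, and the source may have more. Where it says the series, first, only, none or still open, it means among the compounds named here.

Of the compounds shown here, three from one study have been tested in an ADME assay on HEK293 cells (Homo sapiens) for cytotoxicity, read by CCK-8 assay and cell counting, with a stated time of 2 days; on this read-out lower numbers stand for stronger inhibition and higher numbers for weaker inhibition. Compound 1 `Oc1cccc(-c2cc(-c3ccc(Cl)cc3)nc(-c3cccs3)c2)c1` gives 11800 nM in this assay. Compound 2 `Oc1ccc(-c2cc(-c3ccc(Cl)cc3)nc(-c3ccsc3)c2)cc1` gives 4860 nM in this assay. Compound 3 `Oc1cccc(-c2cc(-c3cccs3)nc(-c3ccccc3Cl)c2)c1` gives 2600 nM in this assay. The difference between the core of compound 1 and the core of compound 2 is not broken down here; their two values show a lower number for compound 2, a gap that lies beyond the scatter. Compound 2 and compound 3 stand within the scatter of each other.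

Compound 3 arises from compound 1 by 2-chlorophenyl in place of 4-chlorophenyl on an aromatic carbon, and this move gave a 4.5-fold lower number from compound 1 to compound 3 (0.66 log units; beyond the scatter). Compound 4 `Oc1ccc(-c2cc(-c3ccsc3)nc(-c3ccccc3Cl)c2)cc1` is not yet measured in this assay. It arises from compound 2 by 2-chlorophenyl in place of 4-chlorophenyl on an aromatic carbon, the same kind of change, though the surroundings differ: in compound 1 the place is meta to a 3-hydroxyphenyl group and meta to a thiophen-2-yl group, whereas in compound 2 it is meta to a 4-hydroxyphenyl group and meta to a thiophen-3-yl group.

Going by the values given here, because compound 1 to compound 3 showed a 4.5-fold lower number from compound 1 to compound 3 (0.66 log units; beyond the scatter), a step of similar direction is expected from compound 2 to compound 4, tempered somewhat since only one such pair is known, so that a 3.2-fold lower number from compound 2 to compound 4 (0.51 log units; beyond the scatter) is estimated. Compound 4 is therefore expected to give about 1500 nM in this assay, with a likely range from 500 nM to 4500 nM.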

Compound 4, half-maximal inhibitory concentration: 5930 nM
Compound 4: middle estimate off by 4.0-fold (0.60 log units), on the low side; the whole stated range lies below it.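

In this assay, the swap of 4-chlorophenyl for 2-chlorophenyl on the core of compound 2 gave a 1.2-fold higher number from compound 2 to compound 4 (0.09 log units; within the scatter), so on this core the two chlorine placements cannot be told apart. The sizeable step seen on the core of compound 1 therefore did not carry over to the core of compound 2, and the outcome of this change in the series depends on the core that carries it: the same change on two cores in this assay, a 4.5-fold lower number (0.66 log units; beyond the scatter) from compound 1 to compound 3 and a 1.2-fold higher number (0.09 log units; within the scatter) from compound 2 to compound 4, 5.5-fold (0.74 log units) apart, beyond the scatter of two such steps. What this does not show is which part of the core matters, since the two cores differ both in the hydroxyphenyl group (3-hydroxyphenyl against 4-hydroxyphenyl) and in the thiophene group (thiophen-2-yl against thiophen-3-yl), and two pairs give no rule for any further core.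

As far as these compounds go, it remains open how the same swap would behave on a core that pairs the 3-hydroxyphenyl group with a thiophen-3-yl group, or the 4-hydroxyphenyl group with a thiophen-2-yl group, which would separate the two differences. Also open, from the compounds shown here alone, is what a methoxy group, an amine or a carboxylic acid in place of the hydroxyl would do to the values in this assay.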